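Ester to acid across two side chains

This account rests on a few compounds, and the source may have more. Where it says the series, first, only, none or still open, it means among the compounds named here.

Compound 1 `CCCCC1([C@H](O)/C=C/C2CCC(=O)[C@@H]2C/C=C\CCCC(=O)OCC)CCC1` and compound 2 `CCCCC1([C@H](O)/C=C/C2CCC(=O)[C@@H]2C/C=C\CCCC(=O)O)CCC1` share one core and differ only at the ester end. In a functional assay on the whole organism (strain Hartley) for inhibition, with Cavia porcellus as the target, with stated times of 15 min and 2 min (a higher number here means that more compound is needed for the effect, a lower number that less compound is needed), compound 1 gives 0.221 mg/kg. In this assay compound 2 gives 0.0022 mg/kg. The change is hydrogen in place of ethyl on an oxygen next to a carbonyl group, and it made a 100-fold lower number from compound 1 to compound 2 (2.00 log units; beyond the scatter).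

Compound 3 `CCCCC1([C@@H](O)/C=C/C2CCC(=O)[C@@H]2CCCCSCC(=O)OCC)CCC1` carries a different chain on the ring; the difference between the two cores is not broken down here. In this assay compound 3 reaches only a limit, > 0.672 mg/kg, one of the values sitting at the limit of > 0.672 mg/kg in this assay, at which 1 of the 3 values shown sits. Compound 4 `CCCCC1([C@@H](O)/C=C/C2CCC(=O)[C@@H]2CCCCSCC(=O)O)CCC1` has not been measured and differs from compound 3 by hydrogen in place of ethyl on an oxygen next to a carbonyl group, the same change as that from compound 1 to compound 2.

The starting point for compound 3 is a limit, so the size of the step it will make is open; a step like the measured one would still leave compound 4 well short of compound 2. The step from compound 3 to compound 4 is expected to be about an at least 13-fold lower number from compound 3 to compound 4 (1.12 log units; beyond the scatter), judged beside the measured step. Compound 4 is estimated at 0.05 mg/kg, with a wide range from 0.005 mg/kg to 0.7 mg/kg.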

Compound 4, dose for half-maximal effect: 0.606 mg/kg
Beside the measured number, compound 4's estimate is 12-fold (1.08 log units) below it; low and high end bracket the measured number.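

In this assay the change from ethoxycarbonyl to carboxy on the second core gives an at least 1.1-fold lower number from compound 3 to compound 4 (0.04 log units; that floor lies within the scatter). Set beside the earlier step, the two read: the same change on two cores in this assay, a 100-fold lower number (2.00 log units; beyond the scatter) from compound 1 to compound 2 and an at least 1.1-fold lower number (0.04 log units; that floor lies within the scatter) from compound 3 to compound 4; the limit leaves it open whether they differ. Compound 3 holds a limit and not a number, so the true size of the step on its core stays unknown, and the data neither show that the large step on the core of compound 1 carries over to this core nor rule it out: the limit of > 0.672 mg/kg in this assay, at which 1 of the 4 values shown sits.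

The two cores differ in more than one place, so the compounds shown do not say which part of the chain on the ring separates their results. Also open, as far as these compounds go, is how an amide or a methyl ester at the end of the chain would read in this assay on either core, and whether a core carrying the sulfur-containing chain with a different chain length would follow compound 2 or compound 4.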